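This account rests on a few compounds, and the source may have more. Where it says the series, first, only, none or still open, it means among the compounds named here.

Compound 1 `CC(C)(C)c1cc(NC(=O)Nc2ccc(Cl)cc2)n(-c2ccc(OC(F)(F)F)cc2)n1` gives 0.2 degrees C in an assay on isolated protein for inhibition of STE20-like serine/threonine-protein kinase (Homo sapiens), read by thermal shift assay, tested at 10 uM; on this read-out higher numbers stand for stronger stabilisation of the target against heat and lower numbers for weaker stabilisation of the target.
Compound 2 `CC(C)(C)c1cc(NC(=O)Nc2ccc(Cl)cc2)n(-c2ccc(S(C)(=O)=O)cc2)n1` gives 5.2 degrees C in this assay.
Compound 3 `CC(C)(C)c1cc(NC(=O)Nc2ccc(Cl)cc2)n(-c2ccc(NC(=O)C3CC3)cc2)n1` gives 4.1 degrees C in this assay.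

Compound 3 stands second highest of the three measured numbers. Its nearest neighbour is compound 2, and the step of a number 1.1 degrees C lower from compound 2 to compound 3 (beyond the scatter) puts compound 3 a little below it; its furthest is compound 1, and the step of a number 3.9 degrees C higher from compound 1 to compound 3 (beyond the scatter) puts compound 3 well above it. Compound 4 `CC(C)C(=O)Nc1ccc(-n2nc(C(C)(C)C)cc2NC(=O)Nc2ccc(Cl)cc2)cc1` is the next compound, and it differs from compound 3 in one place: isopropyl in place of cyclopropyl on a carbonyl carbon. For the measured compounds named here, none of the measured steps touches this part of the molecule. All three, a number 5.0 degrees C higher from compound 1 to compound 2 (beyond the scatter), a number 3.9 degrees C higher from compound 1 to compound 3 (beyond the scatter) and a number 1.1 degrees C lower from compound 2 to compound 3 (beyond the scatter), replaced the whole substituent on the aromatic carbon, whereas here the (cyclopropylcarbonyl)amino group is kept and only its outer part is reshaped into an isopropylcarbonyl, with the same count of heavy atoms, no donors or acceptors gained or lost and only the three-membered ring given up. With nothing measured that bears on it, the expectation for this assay is a step of a number 0.10 degrees C lower from compound 3 to compound 4 (within the scatter), which is within the scatter. Compound 4 is therefore estimated at 4 degrees C, with a range from 2.5 degrees C to 5.5 degrees C.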

Compound 4, shift of the target's melting temperature: 6.8 degrees C
The estimate for compound 4 lay 2.8 degrees C below the measured number; the whole stated range lies below it.
By their numbers in this assay, from the lowest: compound 1; then compound 3; then compound 2; then compound 4.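

The step of a number 2.7 degrees C higher from compound 3 to compound 4 (beyond the scatter) in this assay shows that this position responds to the outer part of the amide group, not only to which whole substituent sits on the aromatic carbon, even though isopropyl has the same count of heavy atoms as cyclopropyl and differs from it by giving up the three-membered ring. The change also reverses the order against methylsulfonyl: the step of a number 1.1 degrees C lower from compound 2 to compound 3 (beyond the scatter) had put the (cyclopropylcarbonyl)amino group under it, whereas the step of a number 1.6 degrees C higher from compound 2 to compound 4 (beyond the scatter) puts the (isopropylcarbonyl)amino group over it, and the step of a number 6.6 degrees C higher from compound 1 to compound 4 (beyond the scatter) is the largest gap from trifluoromethoxy seen so far. Nothing measured on these compounds gives a reason for the gain.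

The compounds shown leave open whether the gain belongs to isopropyl alone or would carry over to other groups on the carbonyl carbon, such as ethyl, tert-butyl, cyclobutyl or a longer chain. They also leave open whether the same change would count for as much with something other than the chlorophenyl urea part of the shared core.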